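Hydroxy in Place of Ethoxy: Expected Efficacy of Compound 3

The source may report more compounds than this note shows. Statements on the series, on what has been measured and on what is new or still open speak of the compounds shown alone.

Compound 1 `CCO[C@]1(c2ccc(OCc3c(-c4c(Cl)cccc4Cl)noc3C3CC3)cc2Cl)C[C@H](c2cccc(C(=O)O)c2)C1` was tested in an assay on isolated protein for agonist activity at Bile acid receptor (Homo sapiens), read by FRET (a higher number here means a larger maximal response, a lower number a smaller maximal response), and gives 94%. Compound 2 `O=C(O)c1ccc(C2CC2c2ccc(OCc3c(-c4c(Cl)cccc4Cl)noc3C3CC3)cc2Cl)cn1` gives 101% in this assay, a number within the scatter of that of compound 1, so the two stand together on the numbers shown. Compound 3 `O=C(O)c1cccc([C@H]2C[C@](O)(c3ccc(OCc4c(-c5c(Cl)cccc5Cl)noc4C4CC4)cc3Cl)C2)c1` has not been measured. It differs from compound 1 by hydrogen in place of ethyl on an oxygen on a saturated carbon. Going by the values given here, no step between measured compounds covers this change, and the step of a number 1 percentage points higher from compound 1 to compound 3 (within the scatter) is expected to stay within the scatter, in no particular direction. Compound 3 is therefore estimated at 95%, in the range 75% to 110%.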

Compound 3, largest response reached (reported as efficacy), in percent of the reference or control that the assay uses: 100%
Compound 3: middle estimate off by 5 percentage points, on the low side; low and high end bracket the measured number.
By their numbers in this assay, from the lowest: compounds 1, 3 and 2 (each within the scatter of the next).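

In this assay, replacing ethyl with hydrogen on the oxygen on a saturated carbon gives a number 6 percentage points higher from compound 1 to compound 3 (within the scatter). The ethyl is therefore not required at this position for the maximal response, and a free hydroxy fits there as well as ethoxy does in this read-out. No available evidence bears on why the two compounds stand together. As far as these compounds go, it remains open whether an amine or a longer chain such as butoxy on the same saturated carbon would stand with compound 1 and compound 3 . From the compounds shown here alone, whether the change from ethoxy to hydroxy would read the same way with another core also remains open.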